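This account rests on a few compounds, and the source may have more. Where it says the series, first, only, none or still open, it means among the compounds named here.

Of the compounds shown here, three have so far been tested in a functional assay on the whole organism for inhibition, with Rattus norvegicus as the target; on this read-out higher numbers stand for an effect only at larger amounts of compound and lower numbers for an effect already at smaller amounts. Compound 2 `Cc1ccc2c(c1)c(C1CCN(CCN3CCNC3=O)CC1)cn2-c1ccc(F)cc1` gives 0.0083 umol/kg, the lowest of the two actual numbers. Compound 3 `Fc1ccc(-n2cc(C3=CCNCC3)c3cc(Cl)ccc32)cc1` gives 1.5 umol/kg, a higher number than that of compound 2 and well beyond the usual scatter. Compound 1 `O=C1N(CCN2CCC(c3cn(-c4ccc(F)cc4)c4ccc(Cl)cc34)CC2)CCN1c1ccccc1` reads > 0.15 umol/kg, which is a limit of the assay and not a number.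

Compound 4 `O=C1NCCN1CCN1CCC(c2cn(-c3ccc(F)cc3)c3ccc(C(F)(F)F)cc23)CC1` has not yet been measured. Among the compounds with values here, it is compound 2 with trifluoromethyl in place of methyl on an aromatic carbon, the only structural change: trifluoromethyl in place of methyl on an aromatic carbon. No measured pair among these compounds shows what this exchange does, so the expectation rests on the single reference point of compound 2 at 0.0083 umol/kg. In this assay, the step of a 1.8-fold higher number from compound 2 to compound 4 (0.26 log units; within the scatter) is expected to be small, towards a slightly higher number and not beyond the scatter. For compound 4 the estimated value is 0.015 umol/kg, with an expected range from 0.004 umol/kg to 0.06 umol/kg.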

Compound 4, dose for half-maximal effect: 0.11 umol/kg
The estimate for compound 4 lay 7.3-fold (0.87 log units) below the measured number; measured number outside the range, above it.
By their numbers in this assay, from the lowest: compound 2; then compound 4; then compound 3.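

In this assay, the position on the six-membered aromatic ring of carbon only, meta to a fused ring and para to a fused ring, proves sensitive to the group it carries: trifluoromethyl in place of methyl gives a 13-fold higher number from compound 2 to compound 4 (1.12 log units; beyond the scatter). Within the data shown here, this is the first pair that reads this exchange directly, since the earlier compounds held no such pair. The step is large and lies beyond the scatter, so this position cannot be treated as one where the exchange makes little difference, although it rests on a single pair.

The compounds shown leave open what a methoxy group, a nitrile or a plain hydrogen at this position would give, and whether the exchange gives a step of this size with another side chain. Compound 1 offers no help here, as it carries a limit of the assay and not a number: the limit of > 0.15 umol/kg in this assay, at which 1 of the 4 values shown sits.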